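This account rests on a few compounds, and the source may have more. Where it says the series, first, only, none or still open, it means among the compounds named here.

In an ADME assay on S9 fraction from liver (Rattus norvegicus) for metabolic stability, read by LC-MS, using NADPH, with a stated time of 60 min, tested at 10 uM (a higher number here means that more of the compound is left, a lower number that less of the compound is left), compound 1 (`CCC(O)Cc1cc(-c2ccnc3[nH]nc(C(F)(F)F)c23)cc(C2(C#N)CC2)c1`) gives 17% and compound 2 (`COCC(O)Cc1cc(-c2ccnc3[nH]nc(C(F)(F)F)c23)cc(C2(C#N)CC2)c1`) gives 51%, the higher of the two numbers. Compound 3 (`CC(=O)OCCc1cc(-c2ccnc3[nH]nc(C(F)(F)F)c23)cc(C2(C#N)CC2)c1`) differs from compound 2 as follows: acetoxymethyl in place of 1-hydroxy-2-methoxyethyl on a saturated chain carbon bound to an aromatic carbon. Going by the values given here, only one measured step bears on this change: a number 34 percentage points higher from compound 1 to compound 2 (beyond the scatter). That step is large and also falls on this chain, though it is a different change, so it offers only a loose guide. A large downward move is expected, a number 31 percentage points lower from compound 2 to compound 3 (beyond the scatter). For compound 3 the estimated value is 20%, with an expected range of 3% to 42%.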

Compound 3, percent of the compound remaining: 5%
Compound 3: middle estimate off by 15 percentage points, on the high side, within the range that was stated.
By their numbers in this assay, from the lowest: compound 3; then compound 1; then compound 2.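

On the saturated chain carbon bound to an aromatic carbon, acetoxymethyl gives the lowest number of the three in this assay (a number 46 percentage points lower from compound 2 to compound 3 (beyond the scatter)), and it also falls short of 1-hydroxypropyl (a number 12 percentage points lower from compound 1 to compound 3 (beyond the scatter)). The gain seen with methoxy on the hydroxy chain therefore says nothing in favour of this acetoxy chain, which keeps the same count of heavy atoms as 1-hydroxy-2-methoxyethyl but has no hydrogen-bond donor. Nothing at hand explains either step.

Still open, from the compounds shown here alone, is whether the low number belongs to the acetoxy group as a whole. A plain 2-hydroxyethyl chain or an acetamide in its place would separate these readings.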